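Dimethylamino for Chloro on a Second Core

This account rests on a few compounds, and the source may have more. Where it says the series, first, only, none or still open, it means among the compounds named here.

The measured compounds, with their values in a physicochemical assay for lipophilicity; on this read-out lower numbers stand for lower lipophilicity and higher numbers for higher lipophilicity:
compound 1, `O=C1/C(=C/c2ccc(Cl)cc2)CCC/C1=C\c1ccccc1[N+](=O)[O-]`, gives 5.38;
compound 2, `CN(C)c1ccc(/C=C2\CCC/C(=C\c3ccccc3[N+](=O)[O-])C2=O)cc1`, gives 4.8;
compound 3, `O=C1/C(=C/c2ccc(Cl)cc2)CCC/C1=C\c1cccc([N+](=O)[O-])c1`, gives 5.58.

Compounds 1 and 2 share a core and differ in one place: dimethylamino in place of chloro on an aromatic carbon. This single change gave a number 0.58 log units lower from compound 1 to compound 2 (beyond the scatter) in this assay. Compound 3 carries the same chloro group as compound 1 but on a core that is built from the same atoms joined differently; the difference between the two cores is not broken down here. In this assay the values of compound 3 and compound 1 lie within the scatter of each other, so no order between them can be read, while compound 3 stands well apart from compound 2.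

Compound 4, `CN(C)c1ccc(/C=C2\CCC/C(=C\c3cccc([N+](=O)[O-])c3)C2=O)cc1`, is not yet measured. It relates to compound 3 as compound 2 relates to compound 1: dimethylamino in place of chloro on an aromatic carbon. The place lines of the two changes agree word for word, so this is the same change on a second core. For the measured compounds named here, the expectation is that compound 4 will show a step from compound 3 of about a number 0.58 log units lower from compound 3 to compound 4 (beyond the scatter) in this assay, resting on the single earlier example, a number 0.58 log units lower from compound 1 to compound 2 (beyond the scatter), and on the starting point of compound 3 at 5.58. Going by the values given here, with only one prior example, the range around that expectation is kept wide. On that basis the estimated value for compound 4 in this assay is 5, with the likely span from 4.65 to 5.35.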

Compound 4, partition coefficient: 5
Compound 4: the middle estimate sits on the measured number at the digits printed; measured number inside the range.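

In this assay, dimethylamino in place of chloro on an aromatic carbon gave a number 0.58 log units lower from compound 3 to compound 4 (beyond the scatter) on the second core, and this matches at the printed digits the earlier step of a number 0.58 log units lower from compound 1 to compound 2 (beyond the scatter) on the first core, so in these two pairs the change carried across with its size intact. With dimethylamino present on both cores, 3-nitrophenyl in place of 2-nitrophenyl gave a number 0.20 log units higher from compound 2 to compound 4 (within the scatter), so this read-out does not separate these two cores in that pair. Two matching pairs are still not a rule for other cores or other groups, and nothing at hand speaks to why the step has this size.

The compounds shown leave open whether a similar step would appear if chloro gave way to a different group, such as a simple amine, a carboxylic acid or a longer chain ending in an amine. They also leave open whether the step would hold on a core carrying a nitrile in place of the nitro group, which would test the change on a core beyond these two closely related ones.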